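A few compounds are considered here, and "the series" means these few. Any claim that something is new, unique, unknown or untested is made for them only; others in the source may bear on it.

Notes on a quinone oxime-ether series in a functional assay on A549 cells (Homo sapiens) for antiproliferative activity; a lower number here means that less compound is needed, a higher number that more compound is needed for the effect.

Compound 1, `CCCCCCCCCCCCO/N=C(\CCCCCC)c1cc(OC)c2c(c1OC)C(=O)C=CC2=O`, carries a dodecyl oxime ether on a hexyl ketoxime. In this assay compound 1 gives only a limit, > 10 ug/mL. Compound 2, `CCCCCC/C(=N\OCCC)c1cc(OC)c2c(c1OC)C(=O)C=CC2=O`, differs from it by hydrogen in place of nonyl on a saturated chain carbon, three bonds along the chain from an oxygen on an unsaturated carbon. In this assay compound 2 likewise gives a limit, > 10 ug/mL. The step that the two limits leave unreadable from compound 1 to compound 2 therefore cannot be read.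

Compound 3, `CCCCCCCCCCCCO/N=C/c1cc(OC)c2c(c1OC)C(=O)C=CC2=O`, keeps the dodecyl chain on an aldoxime; the difference between the core of compound 1 and the core of compound 3 is not broken down here. In this assay compound 3 gives a limit, > 10 ug/mL. All measured values sit at the limit of > 10 ug/mL in this assay, at which 3 of the 3 values shown sit, so no ranking among compound 1, compound 2 and compound 3 is possible.

Compound 4, `CCCO/N=C/c1cc(OC)c2c(c1OC)C(=O)C=CC2=O`, is still to be measured; it differs from compound 3 by hydrogen in place of nonyl on a saturated chain carbon, three bonds along the chain from an oxygen on an unsaturated carbon, the same change as from compound 1 to compound 2. Because the limit of > 10 ug/mL in this assay, at which 3 of the 3 values shown sit, covers every measured member, the step that the limit leaves unreadable from compound 3 to compound 4 is expected to be near zero and unreadable. Compound 4 is estimated at 20 ug/mL, between 8 ug/mL and 60 ug/mL, most likely reported again as a limit.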

Compound 4, concentration for half-maximal effect: > 10 ug/mL
Compound 4: no number, only a limit; the forecaster's own chance of this, stated with the estimate: 85%; the middle value does not contradict the limit.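

Compound 3 and compound 4 are both reported only as limits in this assay, so no step can be read between them and the exchange of nonyl for hydrogen has no measurable size here: the limit of > 10 ug/mL in this assay, at which 4 of the 4 values shown sit.

The compounds shown leave open whether the chain length or the difference between aldoxime and ketoxime has any bearing on the result, and how any one compound ranks against another.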